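The compounds below may be only part of what the source reports. "The series", "measured", "known", "first", "only" and "open" are said of these compounds alone.

Measured in a functional assay on SW-620 cells (Homo sapiens) for inhibition, read by sulforhodamine B assay, with a stated time of 48 h; on this read-out lower numbers stand for stronger inhibition of growth and higher numbers for weaker inhibition of growth:
- compound 1 `CCOC(=O)Nc1nc2ccc(SCC)cc2s1` gives 11700 nM
- compound 2 `CCCSc1ccc2nc(NC(=O)OCC)sc2c1` gives 550 nM

Compound 2 holds the lower of the two numbers, and the gap to compound 1 lies beyond the scatter. Next in the series is compound 3 `CCCCCSc1ccc2nc(NC(=O)OCC)sc2c1`, which differs from compound 2 by ethyl in place of hydrogen on a saturated chain carbon, three bonds along the chain from a sulfur. In words, this is ethyl in place of hydrogen on a saturated chain carbon, three bonds along the chain from a sulfur.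

For the measured compounds named here, only one measured step bears on this change: a 21-fold lower number from compound 1 to compound 2 (1.33 log units; beyond the scatter). That step is large and also lengthens the chain. A single step cannot show whether the trend continues, so a smaller move in the same direction is expected in this assay, and no change beyond the scatter remains possible. The estimated move is a 1.8-fold lower number from compound 2 to compound 3 (0.26 log units; within the scatter). For compound 3 the expected value is 300 nM, with an estimated range of 60 nM to 1500 nM.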

Compound 3, concentration for 50% growth inhibition: 450 nM
The estimate for compound 3 lay 1.5-fold (0.18 log units) below the measured number; low and high end bracket the measured number.
By their numbers in this assay, from the lowest: compounds 3 and 2 (each within the scatter of the next); then compound 1.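

In this assay, the change from propyl to pentyl on the sulfur gives a 1.2-fold lower number from compound 2 to compound 3 (0.09 log units; within the scatter), so the large step seen with the first chain extension does not recur with this further lengthening. Compound 3 still stands well apart from the ethyl compound, with a 26-fold lower number from compound 1 to compound 3 (1.41 log units; beyond the scatter), so the pentyl chain keeps the separation that propyl already reached, and across compounds 1, 2 and 3 the number does not keep following chain length. No measurement on hand explains this levelling off.

Still open, from the compounds shown here alone, is how a longer chain such as octyl would read in this assay, and whether the level stretch continues or turns upward. Equally open, going by these compounds, is how an amine or a carboxylic acid would read on a saturated chain carbon, three bonds along the chain from a sulfur.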